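Dimethylamino in place of methyl on a growth-inhibiting thiosemicarbazone

The compounds below may be only part of what the source reports. "The series", "measured", "known", "first", "only" and "open" are said of these compounds alone.

Measured in a functional assay on K562 cells (Homo sapiens) for cytotoxicity, read by sulforhodamine B assay; on this read-out higher numbers stand for weaker inhibition of growth and lower numbers for stronger inhibition of growth:
Compound 1 `CC1=CC[C@@H]([C@@](C)(O)CCCC(C)(C)NC=S)CC1` gives 16700 nM
Compound 2 `CC1=CC[C@@H]([C@@](C)(O)CCCC(C)(C)NC(=S)N/N=C\c2ccc(C)cc2)CC1` gives 140 nM
Compound 3 `CC1=CC[C@@H]([C@@](C)(O)CCCC(C)(C)NC(=S)N/N=C\c2ccc(O)cc2)CC1` gives 600 nM

Compound 2 has the lowest number of these three. The change to compound 4 `CC1=CC[C@@H]([C@@](C)(O)CCCC(C)(C)NC(=S)N/N=C\c2ccc(N(C)C)cc2)CC1` is dimethylamino in place of methyl on an aromatic carbon, counted as dimethylamino in place of methyl on an aromatic carbon and sitting para to a large group. Going by the values given here, one measured step bears on it, hydroxy replacing that same methyl, which gave a 4.3-fold higher number from compound 2 to compound 3 (0.63 log units; beyond the scatter) and counts as modest. On this single precedent, a modest rise in the number is expected in this assay for this change. The expected step is a 2.1-fold higher number from compound 2 to compound 4 (0.33 log units; beyond the scatter) on this estimate. The estimated value for compound 4 is 300 nM within an expected range of 90 nM to 1000 nM in repeated measurements.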

Compound 4, concentration for 50% growth inhibition: 80 nM
Compound 4: middle estimate off by 3.8-fold (0.57 log units), on the high side; the measured number lies below the stated range.
By their numbers in this assay, from the lowest: compounds 4 and 2 (each within the scatter of the next); then compound 3; then compound 1.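

In this assay, the aromatic carbon para to a large group accepts dimethylamino in place of methyl, with a 1.8-fold lower number from compound 2 to compound 4 (0.24 log units; within the scatter) as the outcome. Dimethylamino in place of hydroxy gives a 7.5-fold lower number from compound 3 to compound 4 (0.88 log units; beyond the scatter) and shows that the rise seen with hydroxy does not hold for every replacement of that methyl. Nothing available explains why these groups differ. On these data alone, whether methoxy or a primary amine at this position would read like compound 4 or like compound 3 remains open. So does the outcome with a carboxylic acid there.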